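From Oxadiazole to Cyanopyrimidine: Estimating Compound 4

A few compounds are considered here, and "the series" means these few. Any claim that something is new, unique, unknown or untested is made for them only; others in the source may bear on it.

Compound 1 `Cc1nnc(N2CCC(C(=O)N3N=CC[C@H]3c3cc(F)cc(F)c3)CC2)o1` — 3.3 h
Compound 3 `Cc1nnc(N2CCC(C(=O)N3N=CC[C@H]3c3ccccc3)CC2)o1` — 3.3 h
Compound 2 `CC1=NN(C(=O)C(C)(C)C)[C@H](c2ccccc2)C1` — 0.617 h

In an ADME assay on cells (Hepatocyte, Homo sapiens) for metabolic stability (on this read-out higher numbers stand for a longer-lived compound and lower numbers for a shorter-lived compound), compound 1 stands level with compound 3 at the digits shown, and together they give the two highest of the three numbers. Compound 2 gives the lowest number, a gap from compound 1 that lies beyond the scatter, but the two structures differ in more than one place, so only the two values themselves can be compared.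

Compound 4 `N#Cc1nccc(N2CCC(C(=O)N3N=CC[C@H]3c3cc(F)cc(F)c3)CC2)n1` differs from compound 1 in one place: 2-cyanopyrimidin-4-yl in place of 5-methyl-1,3,4-oxadiazol-2-yl on an amine nitrogen in a ring. For the measured compounds named here, the only measured single step, no change at the digits printed from compound 1 to compound 3 (within the scatter), concerns the aryl group on the saturated ring carbon, not the group on the ring amine, so no measured step bears directly on the change to compound 4. With nothing in the series pointing one way, the step from compound 1 to compound 4 is expected to be small, a 1.3-fold lower number from compound 1 to compound 4 (0.12 log units; within the scatter), and the range is kept wide. Compound 4 is therefore estimated at 2.5 h, between 1 h and 6 h.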

Compound 4, half-life: 2.1 h
Beside the measured number, compound 4's estimate is 1.2-fold (0.08 log units) above it, and the stated range covers the measured number.
By their numbers in this assay, from the lowest: compound 2; then compounds 4, 1 and 3 (each within the scatter of the next).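

In this assay, for the compounds shown here, the first change at the amine nitrogen in a ring gives a 1.6-fold lower number from compound 1 to compound 4 (0.20 log units; within the scatter), so this position takes 2-cyanopyrimidin-4-yl in place of 5-methyl-1,3,4-oxadiazol-2-yl with a step that stays within the scatter. The earlier single step spoke only to the aryl group on the saturated ring carbon, whereas this one shows that a six-membered aromatic ring carrying a nitrile, with 8 heavy atoms in place of 6, can stand on this nitrogen without a step beyond the scatter. The data at hand offer no measured reason for this result.

The compounds shown leave open whether a group without an aromatic ring on this nitrogen, such as an acetyl group or a carboxylic acid, would behave the same way. They also leave open how 2-cyanopyrimidin-4-yl behaves alongside phenyl rather than 3,5-difluorophenyl.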